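Replacing cyanomethyl: from compound 1 to compound 3

The source may hold more compounds than are shown below. What is called first, only, known or untested is meant among the compounds shown, and "the series" means these compounds.

compound 1 `N#CCn1c(-c2ccco2)nc2ccccc21` gives 88100 nM
compound 2 `N#C/C(=C1/SCC(=O)N1c1ccccc1)n1c(-c2ccco2)nc2ccccc21` gives 39600 nM

In a functional assay on HepG2 cells (Homo sapiens) for cytotoxicity, read by sulforhodamine B assay, with a stated time of 48 h (on this read-out higher numbers stand for weaker inhibition and lower numbers for stronger inhibition), compound 1 has the higher of the two numbers, and compound 2 at 39600 nM lies lower, a gap beyond the usual scatter. In compound 3 `N=C1N=C(n2c(-c3ccco3)nc3ccccc32)CN1` the cyanomethyl on the aromatic nitrogen of the shared core gives way to a group with one five-membered non-aromatic ring with 2 hetero atoms, the counted change being a group of 6 heavy atoms (3 carbon, 3 nitrogen; one five-membered non-aromatic ring with 2 hetero atoms) in place of a group of 3 heavy atoms (2 carbon, 1 nitrogen; no ring), on an aromatic nitrogen on that nitrogen. For the measured compounds named here, no measured pair differs in one place, so no measured step speaks directly to this change. The two values give the only scale in this assay for now, and a modest step toward stronger inhibition is expected. The expected change is a 2.0-fold lower number from compound 1 to compound 3 (0.29 log units; within the scatter) and rests on thin data. For compound 3 the estimated value is 45000 nM with an expected range from 15000 nM to 100000 nM as the upper end.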

Compound 3, half-maximal inhibitory concentration: 63500 nM
The estimate for compound 3 lay 1.4-fold (0.15 log units) below the measured number; the measured number falls inside the stated range.
By their numbers in this assay, from the lowest: compounds 2, 3 and 1 (each within the scatter of the next, the first and the last beyond it).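

In this assay, the aromatic nitrogen of the shared core now has its first step that differs in one place: cyanomethyl gives way to a group of 6 heavy atoms with one five-membered non-aromatic ring with 2 hetero atoms, which gives a 1.4-fold lower number from compound 1 to compound 3 (0.14 log units; within the scatter). This position therefore takes the larger ring-bearing group, with 2 hydrogen-bond donors and no triple bond, without a shift that can be told from the scatter, so the nitrile of cyanomethyl is not required for a number of this size. No measurement at hand bears on why this step is as small as it is.

On these data alone, whether an aminoethyl group, a carboxylic acid or a longer alkyl chain on this nitrogen would move the number beyond the scatter remains open. The compounds shown also offer no replacement for the furan-2-yl group, so its contribution remains open too.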